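The source may report more compounds than this note shows. Statements on the series, on what has been measured and on what is new or still open speak of the compounds shown alone.

- compound 1 `COc1ccc(NC(=O)CCCCCCNC(=O)C(O)(O)C(F)(F)F)cc1`: 4520 nM
- compound 2 `O=C(CCCCCCNC(=O)c1cc(=O)c(O)co1)Nc1ccccc1`: > 100000 nM
- compound 3 `OC(O)(c1c(F)c(F)c(-n2cc(-c3ccccc3)nn2)c(F)c1F)C(F)(F)F`: > 100000 nM

Among the compounds with values here, in a functional assay on HCT-116 cells (Homo sapiens) for inhibition, read by colorimetric assay, with a stated time of 3 days (a higher number here means a weaker inhibitor, a lower number a stronger inhibitor), compound 1 gives 4520 nM, the only true number in this small set. Compound 2 reads > 100000 nM, which is a limit of the assay and not a number. Compound 3 reads > 100000 nM, which is also a limit and not a number.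

Compound 4 `O=C(CCCCCCNC(=O)C(O)(O)C(F)(F)F)Nc1c(F)cc(F)cc1F` has not yet been measured. It keeps the rest of compound 1 and differs in one place: 2,4,6-trifluorophenyl in place of 4-methoxyphenyl on an amide-type nitrogen. In words, it has 2,4,6-trifluorophenyl in place of 4-methoxyphenyl on an amide-type nitrogen.

Within the data shown here, no two measured compounds differ in just one place, so the data show no precedent for this swap. The expectation therefore rests on compound 1 alone, at 4520 nM. The estimated step of a 1.1-fold higher number from compound 1 to compound 4 (0.04 log units; within the scatter) is expected to stay within the usual scatter, with neither direction favoured. For compound 4 the estimated value is 5000 nM, with an expected range of 1500 nM to 20000 nM.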

Compound 4, half-maximal inhibitory concentration: 22200 nM
The estimate for compound 4 lay 4.4-fold (0.65 log units) below the measured number; the measured number lies above the stated range.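

In this assay, 2,4,6-trifluorophenyl in place of 4-methoxyphenyl on the amide-type nitrogen gives a 4.9-fold higher number from compound 1 to compound 4 (0.69 log units; beyond the scatter), a modest weakening that lies beyond the scatter. This shows that the aromatic group at this position is not interchangeable, since changing it alone shifts the reading in these cells. Compound 4 still gives a true number and not a limit, which makes this the one step that can be read in a set with few true numbers: the limit of > 100000 nM in this assay, at which 2 of the 4 values shown sit.

A single swap cannot show whether losing the methoxy group or gaining the three fluorines drives the shift. Going by these compounds, how a cyclohexyl group or a pyridine ring would read on this nitrogen stays open, as does the effect of a longer chain with either aromatic group.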